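Methylsulfonyl in place of methylsulfanyl on compound 2

This account rests on a few compounds, and the source may have more. Where it says the series, first, only, none or still open, it means among the compounds named here.

Measured so far in a functional assay on the whole organism for antagonist activity, with Mus musculus as the target, in the maximal electroshock model; on this read-out lower numbers stand for an effect already at smaller amounts and higher numbers for an effect only at larger amounts of compound:
Compound 1 `Cn1c(-c2ccccc2)nnc1S(C)(=O)=O` gives > 200 mg/kg (a limit)
Compound 2 `CSc1nnc(-c2ccccc2F)n1C` gives > 200 mg/kg (a limit)

Compound 2 stands at > 200 mg/kg, which is a limit and not a number. Compound 3 `Cn1c(-c2ccccc2F)nnc1S(C)(=O)=O` carries methylsulfonyl in place of methylsulfanyl on an aromatic carbon. Compound 1 also carries methylsulfonyl and also gives only a limit, > 200 mg/kg, so no large gain is expected in this assay. The expected change, a number no higher from compound 2 to compound 3 (the limit leaves the size open), is small, at most a modest shift towards smaller amounts. For compound 3 the estimate is 200 mg/kg, with an expected range from 70 mg/kg to 400 mg/kg, and the result may again be only a limit.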

Compound 3, dose for half-maximal effect: > 100 mg/kg
Compound 3 ended at the assay's limit; the forecaster's own chance of this, stated with the estimate: 55%; the middle value does not contradict the limit.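

For the compounds shown here, compound 1, compound 2 and compound 3 all give only limits and not numbers, so no step between them can be read. The compounds shown leave open whether methylsulfonyl in place of methylsulfanyl, or fluoro in place of hydrogen, changes the dose for half-maximal effect at all.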